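A few compounds are considered here, and "the series" means these few. Any claim that something is new, unique, unknown or untested is made for them only; others in the source may bear on it.

Working notes on the series. The shared core of compound 1 `COc1cc(C(=O)c2sc(-c3ccc(Cl)cc3)cc2N)cc(OC)c1OC` is kept throughout. Within the data shown here, in a functional assay on MOLT-4 cells (Homo sapiens) for antiproliferative activity (a lower number here means a stronger inhibitor, a higher number a weaker inhibitor), compound 1 gives 77 nM, the second highest of the three numbers so far. Compound 2 `CCOc1ccc(-c2cc(N)c(C(=O)c3cc(OC)c(OC)c(OC)c3)s2)cc1` gives 240 nM in this assay, and compound 3 `COc1cc(C(=O)c2sc(-c3cccc([N+](=O)[O-])c3)cc2N)cc(OC)c1OC` gives 7.5 nM. The two measured changes from compound 1 run in opposite directions: a 3.1-fold higher number from compound 1 to compound 2 (0.49 log units; beyond the scatter), and a 10-fold lower number from compound 1 to compound 3 (1.01 log units; beyond the scatter), while a 32-fold lower number from compound 2 to compound 3 (1.51 log units; beyond the scatter).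

Compound 4 `COc1cc(C(=O)c2sc(-c3ccsc3)cc2N)cc(OC)c1OC` is not yet measured. The change from compound 1 is thiophen-3-yl in place of 4-chlorophenyl on an aromatic carbon. Among the measured compounds shown here, of the measured steps, only the step from compound 1 to compound 3 replaces the whole ring rather than a single substituent on it, and it shows that an exchange of the ring can move the number well beyond the scatter. For the measured compounds named here, no measured step exchanges the six-membered ring for a five-membered one with one hetero atom, so the direction for compound 4 is open. Absent a closer comparison, compound 4 is expected to sit near compound 1, with the step from compound 1 to compound 4 estimated as a 1.3-fold higher number from compound 1 to compound 4 (0.11 log units; within the scatter), which may well lie within the scatter. The estimate for compound 4 in this assay is 100 nM, with a range from 30 nM to 400 nM.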

Compound 4, half-maximal inhibitory concentration: 8.8 nM
For compound 4 the middle estimate is 11-fold (1.06 log units) above the measured one; measured number outside the range, below it.
By their numbers in this assay, from the lowest: compounds 3 and 4 (each within the scatter of the next); then compound 1; then compound 2.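

In this assay, the thiophen-3-yl ring on this aromatic carbon gives an 8.8-fold lower number from compound 1 to compound 4 (0.94 log units; beyond the scatter) and a 27-fold lower number from compound 2 to compound 4 (1.44 log units; beyond the scatter), which shows that the number at this position can fall well beyond the scatter with a five-membered aromatic ring carrying one hetero atom and no substituent, not only with the 3-nitrophenyl group of compound 3. The step that links the two low compounds is a 1.2-fold higher number from compound 3 to compound 4 (0.07 log units; within the scatter), so among the compounds shown, a nitro group is not required for a number at this level, and two rings that differ in size, hetero atom and substituent cannot be told apart in this assay. No available evidence bears on what lies behind the step from the 4-chlorophenyl to the thiophen-3-yl compound.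

The compounds shown leave open whether the drop follows from the ring sulfur, the smaller ring or the loss of the chloro substituent, since each of these changes at once in the single step. An unsubstituted phenyl ring, a thiophen-2-yl ring and a furan ring at this carbon would separate these readings, and an amine on the phenyl ring would test whether a group other than nitro gives a comparable number.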